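Will compound 3 keep the slower clearance of compound 2?

This account rests on a few compounds, and the source may have more. Where it says the series, first, only, none or still open, it means among the compounds named here.

In an in vitro ADME assay on microsomes from liver (Homo sapiens) for metabolic stability (a higher number here means faster removal of the compound, a lower number slower removal), compound 1 `COc1cccc(C(=O)N2CCC(=CC(=O)N[C@@H]3CCN(Cc4ccc5cc(F)ccc5c4)C3)CC2)c1` gives 500 mL/min/kg and compound 2 `COc1cccc(C(=O)N2CCC(=CC(=O)N[C@@H]3CCN(Cc4ccc5cc(F)ccc5c4)C3)CC2)c1O` gives 162 mL/min/kg, the lower of the two numbers. Compound 3 `O=C(C=C1CCN(C(=O)c2cccc(F)c2)CC1)N[C@@H]1CCN(Cc2ccc3cc(F)ccc3c2)C1` differs from compound 2 by 3-fluorophenyl in place of 2-hydroxy-3-methoxyphenyl on a carbonyl carbon, so the hydroxy is lost. For the measured compounds named here, the one measured step that bears on this is a 3.1-fold lower number from compound 1 to compound 2 (0.49 log units; beyond the scatter), seen with hydroxy in place of hydrogen on an aromatic carbon. Going by the values given here, no measurement yet covers the 3-fluorophenyl group. Some move back upward is therefore expected, an estimated 1.9-fold higher number from compound 2 to compound 3 (0.27 log units; within the scatter) in this assay for this swap. For compound 3 the expected value is 300 mL/min/kg, with an estimated range from 130 mL/min/kg to 600 mL/min/kg in this measurement.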

Compound 3, clearance: 459 mL/min/kg
Beside the measured number, compound 3's estimate is 1.5-fold (0.18 log units) below it, and the stated range covers the measured number.
By their numbers in this assay, from the lowest: compound 2; then compounds 3 and 1 (each within the scatter of the next).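

In this assay, 3-fluorophenyl in place of 2-hydroxy-3-methoxyphenyl gives a 2.8-fold higher number from compound 2 to compound 3 (0.45 log units; beyond the scatter), so the slower removal does not carry over to this group. Fluoro in place of methoxy on an aromatic carbon gives a 1.1-fold lower number from compound 1 to compound 3 (0.04 log units; within the scatter), so among these three compounds only compound 2, the one with the hydroxy, stands apart. Nothing measured here explains that difference.

As far as these compounds go, it remains open whether a hydroxy would still give slower removal with fluoro in place of the methoxy. Whether an amine or a carboxylic acid in place of the hydroxy would do the same is also unresolved.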